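This account rests on a few compounds, and the source may have more. Where it says the series, first, only, none or still open, it means among the compounds named here.

Working notes on the series. Among the compounds with values here, compound 2, `C[C@H](NC(=O)Nc1cccc(Cl)c1)c1ccccc1`, gives 99% in an ADME assay on the whole organism with Oryza sativa as the target, tested at 1 uM (a higher number here means a weaker effect of the compound at the concentration tested, a lower number a stronger effect), the higher of the two numbers measured so far. Within the data shown here, compound 1, `CC(C)c1cccc(NC(=O)N[C@@H](C)c2ccccc2)c1`, gives 84% in this assay; the one measured step, a number 15 percentage points higher from compound 1 to compound 2 (beyond the scatter), goes with chloro in place of isopropyl on an aromatic carbon. Compound 3, `C[C@H](NC(=O)Nc1cccc(Cl)c1Cl)c1ccccc1`, is not yet measured. It differs from compound 2 as follows: chloro in place of hydrogen on an aromatic carbon. Among the measured compounds shown here, no measured step covers a chloro entering in place of hydrogen; the step of a number 15 percentage points higher from compound 1 to compound 2 (beyond the scatter) bears on it only in that the chloro-bearing ring already stands at the top of the range, and compound 2 sits close to the ceiling of the read-out, leaving little room upward. For compound 3 the expected step is a number 3 percentage points lower from compound 2 to compound 3 (within the scatter), none beyond the scatter. Compound 3 is therefore estimated at 96%, with a range from 86% to 100%.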

Compound 3, a percentage reported as activity, at one concentration (the size of the read-out at that concentration, not a potency): 100%
Estimate against measurement, compound 3: 4 percentage points below, within the range that was stated.
By their numbers in this assay, from the lowest: compound 1; then compounds 2 and 3 (each within the scatter of the next).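

Within the data shown here, the second chloro added to the ring of compound 2, ortho to a chloro group, is the first change at this position, and in this assay it gives no step beyond the scatter: a number 1 percentage points higher from compound 2 to compound 3 (within the scatter). The earlier step, a number 15 percentage points higher from compound 1 to compound 2 (beyond the scatter), exchanged one group for another and said nothing about adding a second chloro to the ring. Since compound 2 and compound 3 both sit at the ceiling of the read-out, this result cannot show whether the added chloro would further raise the number, and no measurement on hand accounts for the result.

As far as these compounds go, whether an amine or a methoxy group at this position would bring the number down stays open. So does whether the same added chloro would give a comparable step on the isopropyl compound 1, whose number leaves more room upward.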